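Changing the Aryl Group on the Ring Nitrogen

The source may report more compounds than this note shows. Statements on the series, on what has been measured and on what is new or still open speak of the compounds shown alone.

Compound 1 `CC(C(=O)N1CCN(c2ccccc2F)CC1)N1C(=O)CCC1=O`: 50%
Compound 2 `CC(C(=O)N1CCN(c2ccc(F)cc2)CC1)N1C(=O)CCC1=O`: 25%
Compound 3 `CC(C(=O)N1CCN(c2ccccc2Cl)CC1)N1C(=O)CCC1=O`: 25%

Going by the values given here, in a functional assay on the whole organism (strain Swiss) with Mus musculus as the target, in the maximal electroshock model, with a stated time of 1 h, at a dose of 300 mg/kg by the intraperitoneal route (on this read-out higher numbers stand for a stronger effect at the one dose given and lower numbers for a weaker effect), compound 3 stands level with compound 2, and these two are together the lowest of the three numbers; the only step beyond the scatter that reaches compound 3 is a number 25 percentage points lower from compound 1 to compound 3 (beyond the scatter). Compound 4 `Cc1cccc(N2CCN(C(=O)C(C)N3C(=O)CCC3=O)CC2)c1` differs from compound 3 by 3-methylphenyl in place of 2-chlorophenyl on an amine nitrogen in a ring. Two measured steps also exchange the whole aryl group on the ring nitrogen: a number 25 percentage points lower from compound 1 to compound 2 (beyond the scatter) and no change at the digits printed from compound 2 to compound 3 (within the scatter). Among the compounds with values here, neither raised the number, one lowered it modestly and one left it unchanged, and no measured step involves a methyl group. The writer therefore expects a step of no change at the digits printed from compound 3 to compound 4 (within the scatter), not beyond the scatter. Compound 4 is estimated at 25%, within a range from 0% to 50%.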

Compound 4, a percentage reported as activity, at one dose (the size of the read-out at that dose, not a potency): 0%
The estimate for compound 4 lay 25 percentage points above the measured number; the measured number falls inside the stated range.
By their numbers in this assay, from the lowest: compound 4; then compounds 2 and 3 (each within the scatter of the next); then compound 1.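

In this assay, going by these compounds alone, the 3-methylphenyl group takes the number below the level shared by the two lowest earlier compounds, giving a number 25 percentage points lower from compound 3 to compound 4 (beyond the scatter) and also a number 25 percentage points lower from compound 2 to compound 4 (beyond the scatter) as the first aryl exchanges to pass below that level. Against the 2-fluorophenyl group the same exchange gives a number 50 percentage points lower from compound 1 to compound 4 (beyond the scatter) as the only large step in the set, so compound 4 is the lowest of the four. No measurement available here explains this loss. The compounds leave open whether the drop goes with the methyl group itself or with where it sits on the phenyl ring. As far as these compounds go, how a methoxy or trifluoromethyl group, or an unsubstituted phenyl, would read out at this ring nitrogen also stays open.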